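The source may report more compounds than this note shows. Statements on the series, on what has been measured and on what is new or still open speak of the compounds shown alone.

Of the compounds shown here, three built on a sulfonyl-indole scaffold have been measured in an assay on isolated protein for displacement of a labelled ligand from 5-hydroxytryptamine receptor 6 (Homo sapiens), read by scintillation counting, with a stated time of 1 h; a lower number here means a stronger inhibitor, a higher number a weaker inhibitor. Compound 1, `CN(C)c1cccc2c1ccn2S(=O)(=O)c1ccccc1`, gives 65 nM. Compound 2, `O=S(=O)(c1ccccc1)n1ccc2c(-c3ccccc3)cccc21`, differs from compound 1 by phenyl in place of dimethylamino on an aromatic carbon; compound 2 gives 162 nM, and that single change made a step of a 2.5-fold higher number from compound 1 to compound 2 (0.40 log units; beyond the scatter). Compound 3, `CN(C)c1ccc2ccn(S(=O)(=O)c3ccccc3)c2c1`, carries the same atoms as compound 1 joined differently; how its core differs from that of compound 1 is not broken down here. In this assay compound 3 gives 211 nM, which lies within the usual scatter of the value of compound 2.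

Compound 4, `O=S(=O)(c1ccccc1)n1ccc2ccc(-c3ccccc3)cc21`, is not yet measured. It differs from compound 3 by phenyl in place of dimethylamino on an aromatic carbon. Within the data shown here, this is the same kind of change as the one from compound 1 to compound 2, though the place is not identical: there the new group sat ortho to a fused ring and meta to a fused ring, whereas here it sits meta to a fused ring and para to a fused ring. Among the measured compounds shown here, the step from compound 3 to compound 4 is expected to be about a 2.4-fold higher number from compound 3 to compound 4 (0.37 log units; beyond the scatter), because the earlier step of a 2.5-fold higher number from compound 1 to compound 2 (0.40 log units; beyond the scatter) gives the only guide. Compound 4 is therefore estimated at 500 nM, with a likely range from 200 nM to 1300 nM.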

Compound 4, inhibition constant: 178 nM
Compound 4: middle estimate off by 2.8-fold (0.45 log units), on the high side; the whole stated range lies above it.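

In this assay, putting phenyl in place of dimethylamino on the second core gave a 1.2-fold lower number from compound 3 to compound 4 (0.07 log units; within the scatter), so on this core the swap shows no real effect on the reading. Among these compounds, the same swap therefore did not carry over unchanged from one core to the other, and a step seen on one core is a poor guide to the step on the other: the same change on two cores in this assay, a 2.5-fold higher number (0.40 log units; beyond the scatter) from compound 1 to compound 2 and a 1.2-fold lower number (0.07 log units; within the scatter) from compound 3 to compound 4, 3.0-fold (0.47 log units) apart, beyond the scatter of two such steps This rests on only two pairs, and the two cores hold the group at different places, so the data cannot say what sets the two steps apart or how any other change would carry across.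

The compounds shown leave open how a small amine such as methylamino, or a ring amine such as piperazine, would read at either place on these cores. They also leave open whether an ether such as methoxy would follow the dimethylamino compounds, the phenyl compounds, or neither.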